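Dimethylamino in Place of Ethoxy on a Carbonyl Carbon

The source may report more compounds than this note shows. Statements on the series, on what has been measured and on what is new or still open speak of the compounds shown alone.

In a functional assay on MDA-MB-231 cells (Homo sapiens) for inhibition, read by sulforhodamine B assay, with a stated time of 72 h (a lower number here means a stronger inhibitor of growth, a higher number a weaker inhibitor of growth), compound 1 (`CCOC(=O)/C=C/c1ccncc1-c1ccc2ccccc2c1`) gives 8090 nM and has a single neighbour to be compared with. In this assay compound 2 (`CCOC(=O)/C=C/c1ccncc1-c1ccc2cc[nH]c2c1`) gives 7980 nM so the two numbers lie within the scatter of each other and neither can be ranked above the other. Compound 3 (`CN(C)C(=O)/C=C/c1ccncc1-c1ccc2ccccc2c1`) has not yet been measured. It keeps the core of compound 1 and carries dimethylamino in place of ethoxy on a carbonyl carbon. Among the compounds with values here, no measured pair shows this change, so the only anchor is compound 1 at 8090 nM and a small move towards weaker growth inhibition is expected in this assay with wide uncertainty. The expected change is a 1.5-fold higher number from compound 1 to compound 3 (0.17 log units; within the scatter) and it may not clear the scatter. For compound 3 the estimated value is 12000 nM (expected range 4000 nM to 35000 nM).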

Compound 3, concentration for 50% growth inhibition: 7990 nM
For compound 3 the middle estimate is 1.5-fold (0.18 log units) above the measured one, and the stated range covers the measured number.
By their numbers in this assay, from the lowest: compounds 2, 3 and 1 (each within the scatter of the next).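

In this assay, within the data shown here, exchanging ethoxy for dimethylamino on a carbonyl carbon gives a 1.0-fold lower number from compound 1 to compound 3 (0.01 log units; within the scatter), which is the first measured step at this place on the shared core. Ethoxycarbonyl and dimethylcarbamoyl cannot be told apart in this read-out, even though the entering group carries nitrogen where the leaving group carries oxygen and the two differ in their count of hydrogen-bond acceptors. No measured property of either group bears on this result, so the likeness of the two numbers stays unexplained.

Going by these compounds, it remains open whether a carboxylic acid, an unsubstituted carboxamide or a longer ester chain on the same carbonyl carbon would stand apart from these compounds in this assay. On these data alone, it is also open whether the same exchange would read alike on the core of compound 2.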